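A few compounds are considered here, and "the series" means these few. Any claim that something is new, unique, unknown or untested is made for them only; others in the source may bear on it.

Measured in a functional assay on the whole organism for agonist activity, with Mus musculus as the target; on this read-out higher numbers stand for an effect only at larger amounts of compound and lower numbers for an effect already at smaller amounts:
Compound 1 `CC(=O)N(C)CC#CCn1cncc1C`: 45 mg/kg
Compound 2 `COC(=O)NCC#CCn1cncc1C`: > 100 mg/kg

For the measured compounds named here, compound 1 holds the only true number so far. Compound 2 stands at > 100 mg/kg, which is a limit of this assay, as the limit of > 100 mg/kg in this assay, at which 1 of the 2 values shown sits, records.

Compound 3 `Cc1cncn1CC#CCN(C)C(=O)N(C)C` keeps the core of compound 1 but carries dimethylamino in place of methyl on a carbonyl carbon, taking acetyl to dimethylcarbamoyl (dimethylamino in place of methyl on a carbonyl carbon). Going by the values given here, the only measured step that alters this acetyl group is an at least 2.2-fold higher number from compound 1 to compound 2 (0.34 log units; beyond the scatter), and it went toward a higher number. A shift in that direction, small and perhaps within the scatter, is therefore expected: a 1.6-fold higher number from compound 1 to compound 3 (0.19 log units; within the scatter). For compound 3 the estimated value is 70 mg/kg, with an expected range of 25 mg/kg to 200 mg/kg.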

Compound 3, dose for half-maximal effect: > 100 mg/kg
Compound 3 gave a limit, no number; the forecaster's own chance of this, stated with the estimate: 35%; middle value at least 1.4-fold (0.15 log units) from the limit.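

In this assay, the change from methyl to dimethylamino on a carbonyl carbon alone gives an at least 2.2-fold higher number from compound 1 to compound 3 (0.34 log units; beyond the scatter), whereas the earlier step replaced the whole acetyl(methyl)amino group. The amide-type nitrogen and its methyl are kept here, so the carbonyl substituent by itself is enough to shift the read-out beyond the scatter. Compound 1 remains the only compound with a true number, and the value of compound 3 is a limit: the limit of > 100 mg/kg in this assay, at which 2 of the 3 values shown sit.

On these data alone, the true size of this step remains unknown. As far as these compounds go, it also remains open whether an ethyl or a methoxy group on this carbonyl carbon would give a true number.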